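Swapping the Azole on a Short Amide Chain

The source may report more compounds than this note shows. Statements on the series, on what has been measured and on what is new or still open speak of the compounds shown alone.

Of the compounds shown here, two sharing one amide core have been measured in a functional assay for antagonist activity at P2X purinoceptor 7 (Homo sapiens); a lower number here means a stronger inhibitor, a higher number a weaker inhibitor. Compound 1 `CCc1n[nH]c(CC)c1CCC(=O)NCc1ccc(F)cc1Cl` gives 10 nM in this assay. Compound 2 `Cc1c[nH]nc1CCC(=O)NCc1ccc(F)cc1Cl` gives 398 nM in this assay, the higher of the two numbers; compound 1 sits at a lower number, and the gap between them lies beyond the scatter.

Compound 3 `Cc1noc(C)c1CCC(=O)NCc1ccc(F)cc1Cl` differs from compound 2 in one place: 3,5-dimethyl-1,2-oxazol-4-yl in place of 4-methyl-1H-pyrazol-3-yl on a saturated chain carbon, two bonds along the chain from a carbonyl carbon. Among the measured compounds shown here, no measured pair in this set isolates this exact change, so its effect cannot be read directly from the data. What the two measured compounds do show is that the azole carried on the chain matters strongly, since compound 1 and compound 2, which differ only in that ring and its substituents, stand far apart in this assay.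

On that basis compound 3 is expected to land between the two measured values, with the step of a 4.0-fold lower number from compound 2 to compound 3 (0.60 log units; beyond the scatter) estimated to run toward a lower number. The estimate for compound 3 is 100 nM, with a plausible range from 20 nM to 600 nM.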

Compound 3, half-maximal inhibitory concentration: 63.1 nM
Compound 3: middle estimate off by 1.6-fold (0.20 log units), on the high side, and the stated range covers the measured number.
By their numbers in this assay, from the lowest: compound 1; then compound 3; then compound 2.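

Among the compounds shown here, this is the first single-place step in the set, and it gives the position a direct reading: in this assay, 3,5-dimethyl-1,2-oxazol-4-yl in place of 4-methyl-1H-pyrazol-3-yl gives a 6.3-fold lower number from compound 2 to compound 3 (0.80 log units; beyond the scatter). The ring that enters has 0 hydrogen-bond donors against 1 in the ring that leaves, so a donor on the azole is not required for a number lower than that of compound 2, although the step also changes the heavy-atom count, the hetero atoms and the methyl substitution all at once. Nothing at hand gives a reason for the step, so the data show its size and direction but not which of these differences produces it.

The compounds shown leave open how much of the step belongs to the ring itself and how much to its substituents, and a 3,5-dimethyl-1H-pyrazol-4-yl group on the same chain would separate the two. They also leave open whether compound 3 would come closer to compound 1, which stands at 10 nM, with a 3,5-diethyl-1,2-oxazol-4-yl group in place of its 3,5-dimethyl-1,2-oxazol-4-yl group.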